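The compounds below may be only part of what the source reports. "The series", "measured", "known", "first", "only" and "open" are said of these compounds alone.

Compounds measured in a functional assay on isolated protein for agonist activity at Glucose-dependent insulinotropic receptor (Homo sapiens), read by HTRF and cAMP accumulation; a higher number here means a larger maximal response, a lower number a smaller maximal response:
Compound 1, `CC(C)(C)OC(=O)N1CCC(O[C@H]2CC[C@H](Oc3cnc(S(C)(=O)=O)cn3)CC2)CC1`, gives 110%.
Compound 2, `CC1(OC(=O)N2CCC(O[C@H]3CC[C@H](Oc4cnc(S(C)(=O)=O)cn4)CC3)CC2)CC1`, gives 118%.
Compound 3, `CC(C)c1noc(CN2CCC(O[C@H]3CC[C@H](Oc4cnc(S(C)(=O)=O)cn4)CC3)CC2)n1`, gives 102%.

Compound 3 has the lowest of the three numbers; its nearest neighbour is compound 1, with a number 8 percentage points lower from compound 1 to compound 3 (within the scatter), and its furthest is compound 2, with a number 16 percentage points lower from compound 2 to compound 3 (beyond the scatter). Compound 4, `CC(F)Cc1nc(CN2CCC(O[C@H]3CC[C@H](Oc4cnc(S(C)(=O)=O)cn4)CC3)CC2)no1`, is not yet measured. Its difference from compound 3: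
5-(2-fluoropropyl)-1,2,4-oxadiazol-3-yl in place of 3-isopropyl-1,2,4-oxadiazol-5-yl on a saturated chain carbon bound to an amine nitrogen in a ring

Going by the values given here, no measured step touches the oxadiazole itself. The two steps that reach compound 3, a number 8 percentage points lower from compound 1 to compound 3 (within the scatter) and a number 16 percentage points lower from compound 2 to compound 3 (beyond the scatter), exchange a whole carbamate for the oxadiazolylmethyl group, so they bear on the change only loosely, and they are small or modest. On that basis the step to compound 4 is expected to stay within the scatter, in either direction, and the estimate for the step is a number 2 percentage points lower from compound 3 to compound 4 (within the scatter). For compound 4 the expected value in this assay is 100%, with a range from 85% to 115%.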

Compound 4, largest response reached (Emax), in percent of the reference or control that the assay uses: 97%
Beside the measured number, compound 4's estimate is 3 percentage points above it, within the range that was stated.
By their numbers in this assay, from the lowest: compounds 4, 3, 1 and 2 (each within the scatter of the next, the first and the last beyond it).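

In this assay the only exchange shown within the oxadiazole group, 5-(2-fluoropropyl)-1,2,4-oxadiazol-3-yl for 3-isopropyl-1,2,4-oxadiazol-5-yl, gives a number 5 percentage points lower from compound 3 to compound 4 (within the scatter), so the maximal response at this position holds through a change in how the oxadiazole is attached and in its side chain. Against the carbamates the picture sharpens: a number 13 percentage points lower from compound 1 to compound 4 (beyond the scatter) and a number 21 percentage points lower from compound 2 to compound 4 (beyond the scatter), so the gap to both carbamates now lies beyond the scatter, whereas compound 3 stayed within it of compound 1. No supporting data bear on why these numbers fall as they do.

The step alters the oxadiazole attachment and adds fluorine together, and the compounds shown do not separate the two. On these data alone, how a plain propyl chain, a longer alkyl chain or an amide on the amine nitrogen in a ring would read here remains open.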